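This account rests on a few compounds, and the source may have more. Where it says the series, first, only, none or still open, it means among the compounds named here.

Measured compounds:
Compound 1 `ClCc1ccc(Cn2cnc3c(Cl)ncnc32)cc1` — in a functional assay on SK-MEL-2 cells (Homo sapiens) for cytotoxicity, read by sulforhodamine B assay, with a stated time of 48 h (on this read-out lower numbers stand for stronger inhibition of growth and higher numbers for weaker inhibition of growth), compound 1 reaches only the assay limit, > 100000 nM.
Compound 2 `ClCc1ccccc1Cn1cnc2c(Cl)nc(Cl)nc21` — in this assay compound 2 gives 4360 nM.

For the measured compounds named here, compound 2 holds the only real number in this assay; the other value shown is a limit, as the limit of > 100000 nM in this assay, at which 1 of the 2 values shown sits, records. The step under consideration leads from compound 2 to compound 3 `ClCc1ccccc1Cn1cnc2c(Cl)ncnc21`, which is to be measured in this assay. The change is hydrogen in place of chloro on an aromatic carbon, on an aromatic carbon of a six-membered aromatic ring with two nitrogen, between two ring nitrogen atoms, meta to a chloro group and meta and para to the fused ring. Going by the values given here, no step between measured compounds is available to size this change, and compound 1, the other compound that carries only one chloro on the core, shows just a limit rather than a number. Loss of that chloro is therefore expected to weaken growth inhibition, with the step from compound 2 to compound 3 estimated at a 6.9-fold higher number from compound 2 to compound 3 (0.84 log units; beyond the scatter). For compound 3 the expected value in this assay is 30000 nM, within a range from 8000 nM to 100000 nM.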

Compound 3, concentration for total growth inhibition: 18200 nM
Estimate against measurement, compound 3: 1.6-fold (0.22 log units) above; measured number inside the range.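

For the compounds shown here, with this pair, the change of chloro to hydrogen on the aromatic carbon between two ring nitrogen atoms has a measured size for the first time: in this assay, it gives a 4.2-fold higher number from compound 2 to compound 3 (0.62 log units; beyond the scatter). The step shows that, in this pair, the chloro at this position counts towards growth inhibition, yet compound 3 still gives a real number without it, so losing this chloro does not by itself take this pair to the assay limit. Compound 1, which also lacks this chloro, remains a limit and not a number: the limit of > 100000 nM in this assay, at which 1 of the 3 values shown sits.

The compounds shown leave open how other groups on this carbon, such as an amine or a methoxy group, would compare with chloro and hydrogen. Steps involving compound 1 cannot be read, so whether this change would keep its size with the chloromethyl group placed as in compound 1 remains unknown, and a single pair gives no basis for a wider pattern.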